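Trimming Cyclopropylmethoxy to Methoxy in Compound 2

A few compounds are considered here, and "the series" means these few. Any claim that something is new, unique, unknown or untested is made for them only; others in the source may bear on it.

In a functional assay on K562 cells (Homo sapiens) for antiproliferative activity, read by MTT assay, with a stated time of 48 h (a higher number here means a weaker inhibitor of growth, a lower number a stronger inhibitor of growth), compound 2 `COc1ccccc1OCCNc1ccc(=O)n(Cc2ccc(OC)c(OCC3CC3)c2)n1` gives 16600 nM, the lower of the two actual numbers in this small set. Compound 3 `COc1ccccc1OCCNc1ccc(=O)n(Cc2ccc(OC(F)F)c(OCC3CC3)c2)n1` gives 60900 nM, so compound 2 is the stronger inhibitor of growth of that pair. Compound 1 `COc1ccccc1OCCNc1cnn(Cc2ccc(OC)c(OCC3CC3)c2)c(=O)c1Cl` reads > 100000 nM, which is a limit of the assay and not a number.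

Compound 4 `COc1ccc(Cn2nc(NCCOc3ccccc3OC)ccc2=O)cc1OC` has not yet been measured. It departs from compound 2 in one place: hydrogen in place of cyclopropyl on a saturated chain carbon bound to an oxygen on an aromatic ring. This puts hydrogen in place of cyclopropyl on a saturated chain carbon bound to an oxygen on an aromatic ring, so cyclopropylmethoxy becomes methoxy.

Going by the values given here, no measured step touches the cyclopropyl group itself. The nearest evidence is a 3.7-fold higher number from compound 2 to compound 3 (0.56 log units; beyond the scatter), where difluoromethyl stands in place of methyl on an oxygen on an aromatic ring. That is a different group, so it offers only a rough guide to size and a weak hint of direction. Among the compounds with values here, a modest move towards a higher number in this assay is therefore expected, no larger than that step.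

The expected change is a 2.4-fold higher number from compound 2 to compound 4 (0.38 log units; beyond the scatter).

For compound 4 the estimated value is 40000 nM, with an expected range of 12000 nM to 100000 nM.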

Compound 4, concentration for 50% growth inhibition: > 100000 nM
Compound 4: a limit, no number (the forecaster's own chance of this, stated with the estimate: 20%); middle value at least 2.5-fold (0.39 log units) from the limit.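

In this assay the cyclopropylmethoxy group now has a measured step of its own: trimming it to methoxy gives an at least 6.0-fold higher number from compound 2 to compound 4 (0.77 log units; beyond the scatter), so removing the cyclopropyl group from this saturated chain carbon weakens growth inhibition beyond the scatter, something the earlier difluoromethyl step, made on a different group, could not show. Compound 4 reads > 100000 nM, which is a limit of the assay and not a number. The step therefore gives only a lower bound on the size of this change, and the compounds at the limit cannot be placed in order against each other: the limit of > 100000 nM in this assay, at which 2 of the 4 values shown sit.

The compounds shown hold only cyclopropyl and hydrogen on this carbon, so they leave open how an ethyl, an isopropyl or a cyclobutyl group would read there in this assay, and with it whether the ring itself or simply a larger carbon group is what counts. On these data alone, it also stays open whether the same trim would read alike on compound 3, which carries difluoromethyl in place of methyl.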